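Vinyl replaces methyl on the amine-bound chain carbon

The source may report more compounds than this note shows. Statements on the series, on what has been measured and on what is new or still open speak of the compounds shown alone.

Among the measured compounds shown here, compound 3 `CC[N+](C)(C)NCCC(=O)[O-]` gives 140000 nM in an assay for inhibition of gamma-butyrobetaine dioxygenase (Homo sapiens), read by HPLC, with stated times of 15 min and 30 min (a higher number here means a weaker inhibitor, a lower number a stronger inhibitor), one of only two numbers recorded there; compound 2 `C[N+](C)(CCl)CCCC(=O)[O-]` gives 268000 nM, a value within the usual scatter of it. Compound 1 `C[N+](C)(CCCC(=O)[O-])CC1CCC1` returns only a limit, > 1000000 nM, and so contributes no number. For the measured compounds named here, the single measured step, an at least 3.7-fold lower number from compound 1 to compound 2 (0.57 log units; beyond the scatter), concerns a different exchange at the same kind of position and offers no direct guide to a small hydrocarbon swap. Compound 4 `C=CC[N+](C)(C)NCCC(=O)[O-]` differs from compound 3 by vinyl in place of methyl on a saturated chain carbon bound to an amine nitrogen. Going by the values given here, with no closer precedent, a shift no larger than the scatter is expected, and the estimate for compound 4 is 130000 nM, between 50000 nM and 400000 nM. This implies an expected step of a 1.1-fold lower number from compound 3 to compound 4 (0.03 log units; within the scatter).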

Compound 4, half-maximal inhibitory concentration: 119000 nM
For compound 4 the middle estimate is 1.1-fold (0.04 log units) above the measured one; the measured number falls inside the stated range.
By their numbers in this assay, from the lowest: compounds 4, 3 and 2 (each within the scatter of the next, the first and the last beyond it). At a limit, above all of these: compound 1.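

Vinyl in place of methyl on a saturated chain carbon bound to an amine nitrogen gives a 1.2-fold lower number from compound 3 to compound 4 (0.07 log units; within the scatter). Among the compounds shown here, this is the only hydrocarbon exchange at this place with numbers on both sides, and it shows that the added double bond and extra carbon leave the two values indistinguishable. Nothing available gives a reason for this result.

On these data alone, whether a longer chain, a phenyl ring or a propargyl group at this place would read the same stays open. So does whether an ester in place of the carboxylate would leave these values unchanged.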